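From 4-ethoxyphenyl to 2-methylphenyl on the carbonyl carbon

The source may report more compounds than this note shows. Statements on the series, on what has been measured and on what is new or still open speak of the compounds shown alone.

Of the compounds shown here, three sharing one core have numbers so far in a functional assay on A549 cells (Homo sapiens) for antiproliferative activity, read by MTT assay, with a stated time of 48 h (on this read-out lower numbers stand for stronger inhibition and higher numbers for weaker inhibition), for comparison. Compound 1 `COc1ccc(/C=C/c2cc(OC)cc(OC)c2/C=C/C(=O)c2cccc(OC)c2)cc1` gives 6.1 ug/mL there, compound 2 `COc1ccc(/C=C/c2cc(OC)cc(OC)c2/C=C/C(=O)c2ccc(C)cc2)cc1` gives 3.6 ug/mL there, and compound 3 `CCOc1ccc(C(=O)/C=C/c2c(/C=C/c3ccc(OC)cc3)cc(OC)cc2OC)cc1` gives 7.5 ug/mL there. Two steps show where compound 3 stands. The first is a 1.2-fold higher number from compound 1 to compound 3 (0.09 log units; within the scatter) and leaves those two level with each other. The second is a 2.1-fold higher number from compound 2 to compound 3 (0.32 log units; beyond the scatter) and is modest, yet it is the only step among these three compounds that clears the usual scatter.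

The untested compound 4 `COc1ccc(/C=C/c2cc(OC)cc(OC)c2/C=C/C(=O)c2ccccc2C)cc1` differs from compound 3 by a single change 2-methylphenyl in place of 4-ethoxyphenyl on a carbonyl carbon in which 2-methylphenyl stands in place of 4-ethoxyphenyl on a carbonyl carbon. The closest guide is compound 2, which also has a methylphenyl group on the carbonyl carbon, though with the methyl elsewhere on the ring. Going by compound 2 and its 3.6 ug/mL as a reason, compound 4 is expected to land somewhat lower than compound 3, but no tested compound carries the 2-methylphenyl group, so only part of that gap is expected to carry over. In this assay the expected change is a 1.7-fold lower number from compound 3 to compound 4 (0.22 log units; within the scatter) and so stays small. For compound 4 the estimated value is 4.5 ug/mL with an expected range from 2.2 ug/mL to 9 ug/mL in this measurement.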

Compound 4, half-maximal inhibitory concentration: 5.9 ug/mL
Compound 4: the middle estimate sits 1.3-fold (0.12 log units) below what was measured; low and high end bracket the measured number.
By their numbers in this assay, from the lowest: compounds 2, 4, 1 and 3 (each within the scatter of the next, the first and the last beyond it).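

In this assay, putting 2-methylphenyl on the carbonyl carbon in place of 4-ethoxyphenyl gives a 1.3-fold lower number from compound 3 to compound 4 (0.10 log units; within the scatter) and so leaves the two compounds level, even though the oxygen and the ethyl chain of the old group are gone. For the compounds shown here, the two other new comparisons also stay within the scatter: 2-methylphenyl in place of 4-methylphenyl gives a 1.6-fold higher number from compound 2 to compound 4 (0.21 log units; within the scatter) and 2-methylphenyl in place of 3-methoxyphenyl gives a 1.0-fold lower number from compound 1 to compound 4 (0.01 log units; within the scatter) so compound 4 sits level with each of the other three, and the only gap beyond the scatter remains the one between compound 2 and compound 3. No measurement shown here explains why these numbers fall where they do.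

From the compounds shown here alone, all four groups at this place are phenyl rings carrying a methyl, methoxy or ethoxy group, so it remains open how the read-out would respond to a ring carrying an amine or a carboxylic acid, or to a longer chain such as butoxy. Whether the narrow spread of these numbers would hold for such groups cannot be judged from these compounds.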